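Side-chain step from compound 3 to compound 4

A few compounds are considered here, and "the series" means these few. Any claim that something is new, unique, unknown or untested is made for them only; others in the source may bear on it.

Values in a functional assay on A-375 cells (Homo sapiens) for cytotoxicity, read by MTT assay, with a stated time of 72 h (a lower number here means a stronger inhibitor, a higher number a weaker inhibitor), as measured so far

- compound 1 `CN(C)CCCCCn1c2c(c3ccccc31)C(=O)c1c[n+]([O-])c3ccccc3c1C2=O` gives 560 nM
- compound 2 `O=C1c2c[n+]([O-])c3ccccc3c2C(=O)c2c1c1ccccc1n2Cc1cn([C@H]2O[C@H](CO)[C@@H](O)[C@H]2O)nn1` gives 340 nM
- compound 3 `CC1(C)OCC(Cn2cc(Cn3c4c(c5ccccc53)C(=O)c3c[n+]([O-])c5ccccc5c3C4=O)nn2)O1` gives 330 nM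

Compound 3 lies within the scatter of both compound 1 and compound 2, so the three values do not separate in this assay.

Compound 4 `O=C1c2c[n+]([O-])c3ccccc3c2C(=O)c2c1c1ccccc1n2Cc1cn(CC(O)CO)nn1` differs from compound 3 by one change, (1,2-dihydroxyethyl in place of 2,2-dimethyl-1,3-dioxolan-4-yl on a saturated chain carbon bound to an aromatic nitrogen), which in words is 1,2-dihydroxyethyl in place of 2,2-dimethyl-1,3-dioxolan-4-yl on a saturated chain carbon bound to an aromatic nitrogen. Cut one bond further out, this reads (2,2-dimethyl-1,3-dioxolan-4-yl)methyl to 2,3-dihydroxypropyl.

Within the data shown here, one measured step bears on this change, a 1.0-fold lower number from compound 2 to compound 3 (0.01 log units; within the scatter), where (2,2-dimethyl-1,3-dioxolan-4-yl)methyl stands in place of 3,4-dihydroxy-5-(hydroxymethyl)oxolan-2-yl on an aromatic nitrogen. That step lies within the scatter. Among the measured compounds shown here, it is a single comparison, and the 2,3-dihydroxypropyl group itself has no measurement yet. On this basis, no step beyond the scatter is expected in this assay. The expected size is a 1.1-fold higher number from compound 3 to compound 4 (0.03 log units; within the scatter), an estimate that rests on that one step. For compound 4 the estimated value is 350 nM, with an expected range from 170 nM to 750 nM.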

Compound 4, half-maximal inhibitory concentration: 440 nM
Compound 4: middle estimate off by 1.3-fold (0.10 log units), on the low side, within the range that was stated.
By their numbers in this assay, from the lowest: compounds 3, 2, 4 and 1 (each within the scatter of the next).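

In this assay, 1,2-dihydroxyethyl in place of 2,2-dimethyl-1,3-dioxolan-4-yl, on a saturated chain carbon bound to an aromatic nitrogen, gives a 1.3-fold higher number from compound 3 to compound 4 (0.12 log units; within the scatter) and thus shows that a group with no ring and with hydrogen-bond donors can stand where a ring group without donors stood, with no step beyond the scatter. The wider comparisons read the same way: 2,3-dihydroxypropyl in place of 3,4-dihydroxy-5-(hydroxymethyl)oxolan-2-yl gives a 1.3-fold higher number from compound 2 to compound 4 (0.11 log units; within the scatter), and 1-(2,3-dihydroxypropyl)-1H-1,2,3-triazol-4-yl in place of 4-(dimethylamino)butyl gives a 1.3-fold lower number from compound 1 to compound 4 (0.10 log units; within the scatter), so the side chains compared with compound 4 do not separate from it in this cell assay. No accompanying measurement offers an explanation for these values.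

Still open, from the compounds shown here alone, is whether a carboxylic acid or a morpholine at this place, in place of the 1,2-dihydroxyethyl group, would give a step beyond the scatter. Also open, going by these compounds, is how a single hydroxyl, as in 3-hydroxypropyl, or a longer chain, as in 3,4-dihydroxybutyl, would compare with the 2,3-dihydroxypropyl group of compound 4.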